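Cytotoxicity notes: aryl for cyclopropyl on the thiophene

The source may hold more compounds than are shown below. What is called first, only, known or untested is meant among the compounds shown, and "the series" means these compounds.

Compound 1 `C[C@H]1[C@H](NCc2cc(C3CC3)cs2)C[C@H]2C[C@@H]1C2(C)C` and compound 2 `C[C@H]1[C@H](NCc2sccc2C2CC2)C[C@H]2C[C@@H]1C2(C)C` share one core. For the measured compounds named here, in an ADME assay on MDCK cells (Canis lupus familiaris) for cytotoxicity, read by microscopy, with a stated time of 48 h (a higher number here means that more compound is tolerated, a lower number that less compound is tolerated), compound 1 gives 25000 nM; in this assay compound 2 gives 25000 nM, level with compound 1 within the scatter, so compound 1 stands on even ground with its only measured neighbour. Compound 3 `C[C@H]1[C@H](NCc2cc(-c3ccsc3)cs2)C[C@H]2C[C@@H]1C2(C)C` differs from compound 1 by thiophen-3-yl in place of cyclopropyl on an aromatic carbon. Going by the values given here, no measured pair of this kind exists, so the step in this assay from compound 1 to compound 3 is expected to stay within the scatter, as no change at the digits printed from compound 1 to compound 3 (within the scatter) states. For compound 3 the estimate in this assay is 25000 nM, in the range 8000 nM to 50000 nM.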

Compound 3, minimum cytotoxic concentration: 25000 nM
Compound 3: the middle estimate sits on the measured number at the digits printed; measured number inside the range.
By their numbers in this assay, from the lowest: compounds 1, 2 and 3 (each within the scatter of the next).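

At this aromatic carbon, thiophen-3-yl in place of cyclopropyl gives no change at the digits printed from compound 1 to compound 3 (within the scatter) in this assay. The earlier pair varied only where cyclopropyl sits on the thiophene, whereas this step shows that the read-out does not separate a three-membered carbon ring from a five-membered aromatic ring with a sulfur at this position. No available evidence bears on the reason for this result.

Still open, going by these compounds, is whether an amine or a carboxylic acid at this aromatic carbon would stay level with compound 1. Also open, on these data alone, is whether a longer chain there would do so.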